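Difluoropiperidine amide tested against three inactive relatives

This account rests on a few compounds, and the source may have more. Where it says the series, first, only, none or still open, it means among the compounds named here.

Measured so far in a functional assay on MIA PaCa-2 cells (Homo sapiens) for inhibition, read by MTT assay, with a stated time of 3 days; a lower number here means a stronger inhibitor, a higher number a weaker inhibitor:
Compound 1 `CCN(CC)S(=O)(=O)c1ccc(S(=O)(=O)N2CCC[C@@H](C(=O)N3CCOCC3)C2)cc1` gives > 10000 nM, a limit of the assay.
Compound 2 `CCN(CC)S(=O)(=O)c1ccc(S(=O)(=O)N2CCC[C@@H](C(=O)N[C@H]3CCOC3)C2)cc1` gives > 10000 nM, also a limit.
Compound 3 `CN(C)S(=O)(=O)c1ccc(S(=O)(=O)N2CCC[C@@H](C(=O)N3CCC(F)(F)CC3)C2)cc1` gives > 3000 nM, again a limit.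

Compound 2 stands among three compounds that all sit at a limit in this assay, two of them at the limit of > 10000 nM in this assay, at which 2 of the 3 values shown sit, and one at the limit of > 3000 nM in this assay, at which 1 of the 3 values shown sits. Going by the values given here, the one step already measured, a step that the two limits leave unreadable from compound 1 to compound 2, cannot be read because both ends are limits.

Compound 4 `CCN(CC)S(=O)(=O)c1ccc(S(=O)(=O)N2CCC[C@@H](C(=O)N3CCC(F)(F)CC3)C2)cc1` differs from compound 2 by the change (4,4-difluoropiperidin-1-yl in place of (oxolan-3-yl)amino on a carbonyl carbon). The closest guide is compound 3, which carries the same 4,4-difluoropiperidin-1-yl group on the carbonyl carbon and also reaches only a limit in this assay. Among the compounds with values here, no measured step shows a gain from any amide group here, so no movement beyond the usual scatter is expected in this assay, and the step that the limit leaves unreadable from compound 2 to compound 4 is estimated to be essentially flat. Compound 4 is therefore expected to give about 12000 nM, within 3000 nM to 40000 nM, most likely reported again only as a limit.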

Compound 4, half-maximal inhibitory concentration: > 10000 nM
Compound 4 gave a limit, no number; the forecaster's own chance of this, stated with the estimate: 85%; the middle value does not contradict the limit.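

In this assay compound 4 gives > 10000 nM, a limit and not a number. Its steps from compound 1, compound 2 and compound 3 cannot be read, with limits at both ends of each. The compounds shown leave open what actual values these four compounds have and how far they differ.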